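The compounds below may be only part of what the source reports. "The series", "measured", "known", "first", "only" and "open" are said of these compounds alone.

Compound 1 `O=C1C(NC2CCCC2)=CC(=O)c2c1nc1n2[C@H]2OC[C@@H](O)[C@H]2OC1` carries a cyclopentylamino group on the shared core. In a functional assay on ECa-109 cells for inhibition, with ECa-109 cell line (Homo sapiens) as the target, read by sulforhodamine B assay (on this read-out lower numbers stand for stronger inhibition and higher numbers for weaker inhibition), compound 1 gives > 16000 nM, which is a limit of the assay and not a number. Compound 2 `CCc1ccc(NC2=CC(=O)c3nc4n(c3C2=O)[C@H]2OC[C@@H](O)[C@H]2OC4)cc1` gives 3080 nM in this assay, and compound 3 `O=C1C=C(Nc2ccc(C(F)(F)F)cc2)C(=O)c2c1nc1n2[C@H]2OC[C@@H](O)[C@H]2OC1` gives 5500 nM. Among the compounds with values here, the one measured step between them, a 1.8-fold higher number from compound 2 to compound 3 (0.25 log units; within the scatter), concerns the substituent on the aromatic ring and not the group attached to the double-bonded ring carbon of the core.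

Compound 4 `O=C1C(N2CCC2)=CC(=O)c2c1nc1n2[C@H]2OC[C@@H](O)[C@H]2OC1` is not yet measured. It differs from compound 1 by azetidin-1-yl in place of cyclopentylamino on a double-bonded ring carbon. Within the data shown here, no measured step covers a change of this kind, and compound 1 itself only reaches (the limit of > 16000 nM in this assay, at which 1 of the 3 values shown sits), so the step cannot be anchored at either end. The expectation is therefore that compound 4 stays near the level of compound 1 rather than near the level of compounds 2 and 3. The step that the limit leaves unreadable from compound 1 to compound 4 is expected to be small, with no direction claimed. For compound 4 the estimate in this assay is 20000 nM, within 6000 nM to 60000 nM.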

Compound 4, half-maximal inhibitory concentration: > 16000 nM
Compound 4 gave a limit, no number; the forecaster's own chance of this, stated with the estimate: 60%; the middle value is on the limit's open side.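

Compound 4 gives > 16000 nM in this assay, which is a limit and not a number. Compound 1 gives > 16000 nM, also a limit. No step can be read between compound 1 and compound 4. The compounds shown leave open whether azetidin-1-yl and cyclopentylamino differ at all on the shared core.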